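The source may report more compounds than this note shows. Statements on the series, on what has been measured and on what is new or still open speak of the compounds shown alone.

Compound 2 `C=CC(=O)Nc1cccc(NC(=O)CSc2nc(Nc3cccc(C)c3)c3ccccc3n2)c1` gives 29200 nM in a functional assay on PC-3 cells (Homo sapiens) for inhibition, read by MTT assay, with a stated time of 72 h; on this read-out lower numbers stand for stronger inhibition and higher numbers for weaker inhibition; that is the lowest of the two numbers measured, and its nearest neighbour, compound 1 `C=CC(=O)Nc1cccc(NC(=O)CSc2nc(Nc3cccc([N+](=O)[O-])c3)c3ccccc3n2)c1`, gives 46300 nM, a gap within the scatter. Compound 3 `C=CC(=O)Nc1cccc(NC(=O)CSc2nc(Nc3ccc(C(F)(F)F)cc3)c3ccccc3n2)c1` carries 4-(trifluoromethyl)phenyl in place of 3-methylphenyl on a nitrogen on an aromatic ring. For the measured compounds named here, no measured step tests this exact change; the only step available, a 1.6-fold lower number from compound 1 to compound 2 (0.20 log units; within the scatter), swapped groups on the same ring and stayed within the scatter. The change to compound 3 is therefore expected to give no step beyond the scatter, a 1.0-fold higher number from compound 2 to compound 3 (0.01 log units; within the scatter). Compound 3 is estimated at 30000 nM, with a range from 10000 nM to 90000 nM.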

Compound 3, half-maximal inhibitory concentration: 12500 nM
Estimate against measurement, compound 3: 2.4-fold (0.38 log units) above; the range from low to high includes it.
By their numbers in this assay, from the lowest: compound 3; then compounds 2 and 1 (each within the scatter of the next).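

On the nitrogen of the shared core, the aryl group can shift the number beyond the scatter, which the earlier swap of groups on the same ring did not do: in (this assay), the new group gives (a 2.3-fold lower number from compound 2 to compound 3 (0.37 log units; beyond the scatter)) and (a 3.7-fold lower number from compound 1 to compound 3 (0.57 log units; beyond the scatter)). Both steps are modest, so this position responds only mildly so far. Nothing available explains the shift.

Compound 3 differs from compound 2 in both the group and its ring position, so the two effects cannot be separated. Going by these compounds, how this nitrogen's ring would respond to an amine or a carboxylic acid also remains open.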